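This account rests on a few compounds, and the source may have more. Where it says the series, first, only, none or still open, it means among the compounds named here.

Compound 2 `Cc1nc(N)c2c(-c3cc4ccccc4o3)cn([C@@H]3O[C@H](CO)[C@@H](O)[C@H]3O)c2n1` gives 91800 nM in an ADME assay on MRC5 cells (Homo sapiens), read by MTT assay, with a stated time of 72 h; on this read-out lower numbers stand for stronger inhibition and higher numbers for weaker inhibition; this is the highest of the two numbers recorded there. Its nearest neighbour is compound 1 `Nc1nc(N)c2c(-c3cc4ccccc4o3)cn([C@@H]3O[C@H](CO)[C@@H](O)[C@H]3O)c2n1`, which in this assay gives 78500 nM. Among the measured compounds shown here, the single measured step, a 1.2-fold higher number from compound 1 to compound 2 (0.07 log units; within the scatter), lies within the scatter, so the two compounds cannot be separated on this read-out. Compound 3 `Cc1nc(N)c2c(-c3ccco3)cn([C@@H]3O[C@H](CO)[C@@H](O)[C@H]3O)c2n1` has not yet been measured. It differs from compound 2 in one place: furan-2-yl in place of 1-benzofuran-2-yl on an aromatic carbon. For the measured compounds named here, no measured step bears on this change. Going by the values given here, the only step recorded, amino to methyl, touches a different part of the shared core, and no pair of measured compounds differs by the exchange of 1-benzofuran-2-yl for furan-2-yl. The data therefore give no basis for expecting a shift beyond the scatter in either direction in this assay. Compound 3 is thus expected to show a step of a 1.1-fold higher number from compound 2 to compound 3 (0.04 log units; within the scatter) in this assay, with a range widened to reflect the missing precedent. Compound 3 is estimated at 100000 nM, within a range from 40000 nM to 250000 nM.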

Compound 3, half-maximal inhibitory concentration: > 100000 nM
Compound 3: only a limit was reported; the forecaster's own chance of this, stated with the estimate: 20%; the middle value sits exactly at the limit.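

In this assay, compound 3 is reported only as a limit of the assay, not as a number: > 100000 nM. Among the compounds shown here, this is the first change seen at the aromatic carbon two ring bonds from the ring nitrogen. Taking away the six-membered aromatic ring of carbon only, and leaving furan-2-yl in place of 1-benzofuran-2-yl, gives an at least 1.0-fold higher number from compound 2 to compound 3 (0.03 log units; that floor lies within the scatter), so the smaller group brings no lower number on this read-out, although the floor of the step does not separate the two compounds. The true size of the step stays unfixed because the reading of compound 3 stops at the end of the measurable range: the limit of > 100000 nM in this assay, at which 1 of the 3 values shown sits.

The compounds shown leave open how far the number of compound 3 lies past that limit, and whether furan-2-yl would behave in the same way alongside the amino group of compound 1. They also leave open what a phenyl ring, a thiophen-2-yl ring, an amine or a carboxylic acid would do on this same carbon.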